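An Amino Group Added to Two Nucleoside Cores

The source may report more compounds than this note shows. Statements on the series, on what has been measured and on what is new or still open speak of the compounds shown alone.

Compound 1 `COc1ncnc2c1c(-c1ccoc1)cn2[C@@H]1O[C@H](CO)[C@@H](O)[C@H]1O`: 110 nM
Compound 2 `COc1nc(N)nc2c1c(-c1ccoc1)cn2[C@@H]1O[C@H](CO)[C@@H](O)[C@H]1O`: > 20000 nM, a limit of the assay
Compound 3 `O=c1[nH]cnc2c1c(-c1cc3ccccc3o1)cn2[C@@H]1O[C@H](CO)[C@@H](O)[C@H]1O`: > 20000 nM, a limit of the assay

In a functional assay on HCT-116 cells (Homo sapiens), read by MTT assay, with a stated time of 72 h (on this read-out lower numbers stand for stronger inhibition and higher numbers for weaker inhibition), compound 1 gives 110 nM. For compound 2 this assay reports only a limit, > 20000 nM. Compound 2 differs from compound 1 by amino in place of hydrogen on an aromatic carbon, and the step is an at least 180-fold higher number from compound 1 to compound 2 (2.25 log units; beyond the scatter). The values shown cluster at the limit of > 20000 nM in this assay, at which 2 of the 3 values shown sit.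

For compound 3 this assay likewise reports only a limit, > 20000 nM. The difference between the core of compound 3 and the core of compound 1 is not broken down here.

Compound 4 `Nc1nc2c(c(-c3cc4ccccc4o3)cn2[C@@H]2O[C@H](CO)[C@@H](O)[C@H]2O)c(=O)[nH]1` has not yet been measured. It differs from compound 3 by amino in place of hydrogen on an aromatic carbon. This is the same kind of change as that from compound 1 to compound 2, though not the same: in compound 2 the amino group is meta to a methoxy group (2 heavy atoms), whereas in compound 4 it is meta to a group of 1 heavy atom.

Compound 3 already sits at a limit, and because the same kind of change gave an at least 180-fold higher number from compound 1 to compound 2 (2.25 log units; beyond the scatter), compound 4 is expected to give about 30000 nM in this assay, most likely again as a limit, within an expected range of 20000 nM to 100000 nM. The step this estimate implies, a step that the limit leaves unreadable from compound 3 to compound 4, is expected to stay within scatter, as both values would sit at or beyond the limit.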

Compound 4, half-maximal inhibitory concentration: > 100000 nM
Compound 4 gave a limit, no number (the forecaster's own chance of this, stated with the estimate: 95%); middle value at least 3.3-fold (0.52 log units) away from the limit.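

Compound 3 and compound 4 are both reported in this assay only as limits of the assay, so the step between them cannot be read. The compounds shown leave open whether amino in place of hydrogen on an aromatic carbon changes anything on the core of compound 3, and so whether the step seen on the core of compound 1 has any counterpart there.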